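The source may hold more compounds than are shown below. What is called first, only, known or untested is meant among the compounds shown, and "the series" means these compounds.

The measured compounds:
Compound 1, `CCn1c(C(=O)NCCNC(=O)OC(C)(C)C)ccc1C(CC)(CC)c1ccc(OCS(=O)(=O)c2ccccc2)c(C)c1`, gives only a limit of > 50000 nM in a functional assay on BXPC-3 cells (Homo sapiens) for antiproliferative activity, read by MTT assay, with a stated time of 24 h; on this read-out higher numbers stand for weaker inhibition and lower numbers for stronger inhibition.
Compound 2, `CCn1c(C(=O)N[C@H](C)CO)ccc1C(CC)(CC)c1ccc(OCS(=O)(=O)c2ccccc2)c(C)c1`, gives 10000 nM in this assay.
Compound 3, `CCn1c(C(=O)N[C@H](CO)C(C)C)ccc1C(CC)(CC)c1ccc(OCS(=O)(=O)c2ccccc2)c(C)c1`, gives 7720 nM in this assay.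

Within this assay compound 2 holds the higher of the two numbers that are not limits; compound 3 is nearest, and the step of a 1.3-fold lower number from compound 2 to compound 3 (0.11 log units; within the scatter) lies within the scatter. The value of compound 1 is a limit (the limit of > 50000 nM in this assay, at which 1 of the 3 values shown sits), so the steps of an at least 5.0-fold lower number from compound 1 to compound 2 (0.69 log units; beyond the scatter) and an at least 6.4-fold lower number from compound 1 to compound 3 (0.81 log units; beyond the scatter) are lower bounds on what replacing 2-((tert-butoxycarbonyl)amino)ethyl achieves.

Compound 4, `CCn1c(C(=O)N[C@H](C(=O)O)C(C)C)ccc1C(CC)(CC)c1ccc(OCS(=O)(=O)c2ccccc2)c(C)c1`, is not yet measured. It differs from compound 2 in one place: 1-carboxy-2-methylpropyl in place of 1-(hydroxymethyl)ethyl on an amide-type nitrogen. Within the data shown here, only one measured step touches the same position without a limit, a 1.3-fold lower number from compound 2 to compound 3 (0.11 log units; within the scatter), which exchanges 1-(hydroxymethyl)ethyl for 1-(hydroxymethyl)-2-methylpropyl and stays within the scatter. No measured compound carries a 1-carboxy-2-methylpropyl group, so that part of the change has no precedent among these compounds. Because the branching change alone gave a 1.3-fold lower number from compound 2 to compound 3 (0.11 log units; within the scatter), the expected step is a 1.5-fold higher number from compound 2 to compound 4 (0.18 log units; within the scatter), with wide uncertainty. Compound 4 is estimated at 15000 nM in this assay, between 5000 nM and 50000 nM.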

Compound 4, half-maximal inhibitory concentration: 16200 nM
For compound 4 the middle estimate is 1.1-fold (0.03 log units) below the measured one; the range from low to high includes it.
By their numbers in this assay, from the lowest: compounds 3, 2 and 4 (each within the scatter of the next, the first and the last beyond it). At a limit, above all of these: compound 1.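

The exchange of hydroxymethyl for carboxy on the otherwise unchanged chain at this amide-type nitrogen gives a 2.1-fold higher number from compound 3 to compound 4 (0.32 log units; beyond the scatter), so in this assay this position responds to what ends the chain, while the full replacement of 1-(hydroxymethyl)ethyl by 1-carboxy-2-methylpropyl gives only a 1.6-fold higher number from compound 2 to compound 4 (0.21 log units; within the scatter). The 1-carboxy-2-methylpropyl group also leaves a gap to the 2-((tert-butoxycarbonyl)amino)ethyl group, an at least 3.0-fold lower number from compound 1 to compound 4 (0.48 log units; beyond the scatter), and that gap is only a lower bound. Compound 1 is held at a limit: the limit of > 50000 nM in this assay, at which 1 of the 4 values shown sits.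

As far as these compounds go, it remains open whether a methyl ester of the carboxylic acid, a primary amine or a longer chain in the same place would carry the number further from the values seen so far. From the compounds shown here alone, it is equally open whether carboxy on the unbranched-at-the-end 1-carboxyethyl group would give the same step as it does on the 1-carboxy-2-methylpropyl group, and whether the opposite configuration at the defined stereocentre would change any of these readings.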